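This account rests on a few compounds, and the source may have more. Where it says the series, first, only, none or still open, it means among the compounds named here.

Compound 2 `FC(F)(F)c1ccc(C2=NN(C(=S)Nc3ccccc3)C(c3ccc4c(c3)OCCO4)C2)cc1` is the weaker of two close relatives. For the measured compounds named here, in a functional assay on WM 266-4 cells (Homo sapiens) for antiproliferative activity, read by MTT assay, with a stated time of 48 h (on this read-out higher numbers stand for weaker inhibition of growth and lower numbers for stronger inhibition of growth), compound 2 gives 52400 nM, the highest of the two numbers so far. Its neighbour, compound 1 `Cc1ccc(C2=NN(C(=S)Nc3ccccc3)C(c3ccc4c(c3)OCCO4)C2)cc1`, differs from it only in one group on the outer ring, and in this assay compound 1 gives 10300 nM. The measured step shows a 5.1-fold higher number from compound 1 to compound 2 (0.71 log units; beyond the scatter), so exchanging that one group already moves the number well beyond the usual scatter.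

Compound 3 `CSc1ccc(C2=NN(C(=S)Nc3ccccc3)C(c3ccc4c(c3)OCCO4)C2)cc1` keeps the shared core of compound 2 and changes the same spot: methylsulfanyl in place of trifluoromethyl on an aromatic carbon. Going by the values given here, only the step from compound 1 to compound 2 bears on this change, and it concerns a different incoming group, so it gives direction rather than a firm size. Because a 5.1-fold higher number from compound 1 to compound 2 (0.71 log units; beyond the scatter) shows that removing the methyl in favour of trifluoromethyl raised the number strongly, the reverse removal of the trifluoromethyl is expected to lower it again, though not necessarily all the way back. Compound 3 is therefore expected to give 15000 nM, within a range from 4000 nM to 60000 nM, an expected step of a 3.5-fold lower number from compound 2 to compound 3 (0.54 log units; beyond the scatter).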

Compound 3, concentration for 50% growth inhibition: 197000 nM
Compound 3: the middle estimate sits 13-fold (1.12 log units) below what was measured; measured number outside the range, above it.
By their numbers in this assay, from the lowest: compound 1; then compound 2; then compound 3.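

Methylsulfanyl does not bring the number back down from the trifluoromethyl level in this assay; instead, the exchange gives a 3.8-fold higher number from compound 2 to compound 3 (0.58 log units; beyond the scatter) and makes compound 3 the weakest of the three growth inhibitors shown. Compared directly with methyl, the same group gives a 19-fold higher number from compound 1 to compound 3 (1.28 log units; beyond the scatter), a large change from a single group on an aromatic carbon para to a large group, so methyl is the best of the three groups tested here and both alternatives are clearly worse. The data offer no measured explanation for this order.

For the compounds shown here, with only three groups at this position, it remains open whether any other group, such as a methoxy group, a chlorine atom or an amine, would give a number lower than that of compound 1. On these data alone, it is also open whether the same order of methyl, trifluoromethyl and methylsulfanyl would hold if another part of the shared core were changed.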